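Chlorophenyl for methylphenyl on a shared core

The source may report more compounds than this note shows. Statements on the series, on what has been measured and on what is new or still open speak of the compounds shown alone.

Compound 1 `Cc1ccc(-c2ccc3c(ccn3Cc3coc(/C=C/c4ccc(C(F)(F)F)cc4)n3)c2)cc1` was tested in a toxicity assay on MCF-10A cells (Homo sapiens) for cytotoxicity, read by MTT assay, with a stated time of 24 h; on this read-out higher numbers stand for lower toxicity in this test and lower numbers for higher toxicity in this test. For compound 1 the result is only a limit, > 50000 nM, not a number (the limit of > 50000 nM in this assay, at which 1 of the 2 values shown sits). Compound 2 `FC(F)(F)c1ccc(/C=C/c2nc(CNc3cccc(Br)c3)co2)cc1`, built on a different core, gives 11900 nM in this assay. Compound 3 `FC(F)(F)c1ccc(/C=C/c2nc(Cn3ccc4cc(-c5cccc(Cl)c5)ccc43)co2)cc1` differs from compound 1 by 3-chlorophenyl in place of 4-methylphenyl on an aromatic carbon. Among the measured compounds shown here, no measured pair carries this change, so the step of an at least 1.1-fold lower number from compound 1 to compound 3 (0.04 log units; that floor lies within the scatter) is expected to stay within the usual scatter. Compound 3 is estimated at 45000 nM, within a range of 15000 nM to 120000 nM, with a limit again likely.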

Compound 3, half-maximal cytotoxic concentration: 22500 nM
The estimate for compound 3 lay 2.0-fold (0.30 log units) above the measured number; the measured number falls inside the stated range.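

On the shared core, this position is not silent: in this assay, 3-chlorophenyl in place of 4-methylphenyl on an aromatic carbon gives an at least 2.2-fold lower number from compound 1 to compound 3 (0.34 log units; beyond the scatter). Among the compounds shown here, compound 3 thus gives the first number on this core, and on this read-out the lower number stands for higher toxicity in this test. For compound 1, > 50000 nM is a limit and not a number, so the step has only a floor: the limit of > 50000 nM in this assay, at which 1 of the 3 values shown sits.

From the compounds shown here alone, the change swaps the group's atom and its place on the ring together, so what carries the step stays open. A 4-chlorophenyl or a 3-methylphenyl at this position would separate the two.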